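Amide linker in place of sulfonamide on the anilino ring

This account rests on a few compounds, and the source may have more. Where it says the series, first, only, none or still open, it means among the compounds named here.

Compound 1 `CN(C)C(=O)c1cc2cnc(Nc3ccc(S(=O)(=O)NCCCCCN=C=S)cc3)nc2n1C1CCCC1` is the starting point of the series. Going by the values given here, in a functional assay on A549 cells (Homo sapiens) for inhibition, read by CCK-8 assay, with a stated time of 72 h, tested at 1 uM (a higher number here means a stronger effect of the compound at the concentration tested, a lower number a weaker effect), compound 1 gives 56.6%, the highest of the two numbers measured so far. Its nearest neighbour is compound 2 `CN(C)C(=O)c1cc2cnc(Nc3ccc(S(=O)(=O)NCCCCCCN=C=S)cc3)nc2n1C1CCCC1`, which in this assay gives 49.5%. Among the compounds with values here, the single measured step, a number 7.1 percentage points lower from compound 1 to compound 2 (within the scatter), lengthens the chain by one carbon and leaves the read-out within the scatter.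

Compound 3 `CN(C)C(=O)c1cc2cnc(Nc3ccc(NC(=O)CCCCCN=C=S)cc3)nc2n1C1CCCC1` is not yet measured. Its difference from compound 1 is a group of 11 heavy atoms (7 carbon, 2 nitrogen, 1 oxygen, 1 sulfur; no ring) in place of a group of 12 heavy atoms (6 carbon, 2 nitrogen, 2 oxygen, 2 sulfur; no ring), on an aromatic carbon. Within the data shown here, no measured step touches this part of the molecule: the step from compound 1 to compound 2 concerns only the far end of the chain and says nothing about the linker to the aromatic ring. Among the measured compounds shown here, the only guidance is that the one change tried so far left the read-out in this assay within the scatter, so no direction can be argued for compound 3, and the expected step is a number 4.6 percentage points lower from compound 1 to compound 3 (within the scatter), none beyond the scatter. For compound 3 the expected value in this assay is estimated at 52%, with a range from 28% to 74%.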

Compound 3, a percentage reported as inhibition, at one concentration (the size of the read-out at that concentration, not a potency): 56.1%
Compound 3: middle estimate off by 4.1 percentage points, on the low side, and the stated range covers the measured number.
By their numbers in this assay, from the lowest: compounds 2, 3 and 1 (each within the scatter of the next).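

In this assay, going by these compounds alone, replacing the sulfonamide-bearing group with the amide-bearing group on an aromatic carbon, para to a large group, gives a number 0.5 percentage points lower from compound 1 to compound 3 (within the scatter), the first measured step at the linker rather than at the far end of the chain. The exchange takes the group from 4 to 3 hydrogen-bond acceptors, keeps 1 hydrogen-bond donor, and produces no difference beyond the scatter, so the sulfonamide is not needed to keep this single-concentration read-out at the level of compound 1. No measurement bears on how the two linkers compare beyond this read-out, and nothing accounts for the result.

Open, from the compounds shown here alone, is whether this tolerance extends to other linkers on the aromatic carbon, such as a urea or a plain carbon chain, and whether the amide series responds to a longer chain as the sulfonamide pair of compound 1 and compound 2 does. Also open, going by these compounds, is what the isothiocyanate end contributes, which a comparison with an acrylamide or a simple amine at the chain end would address.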